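The source may hold more compounds than are shown below. What is called first, only, known or untested is meant among the compounds shown, and "the series" means these compounds.

Measured compounds: compound 1 `COc1ccc(CNc2nc3cc(N)cc(N)c3nc2-c2ccccc2)cc1OC` and compound 2 `COc1cc(CNc2nc3cc(N)cc(N)c3nc2-c2ccccc2)cc(OC)c1OC`.

In a functional assay on SR cells (Homo sapiens) for inhibition, read by sulforhodamine B assay, with a stated time of 48 h (on this read-out higher numbers stand for lower toxicity in this test and lower numbers for higher toxicity in this test), compound 1 gives < 100000 nM, a limit of the assay rather than a number. Compound 2 in this assay also gives only a limit, < 50200 nM. The step that the two limits leave unreadable from compound 1 to compound 2 is unreadable because the limit of < 100000 nM in this assay, at which 1 of the 2 values shown sits, and the limit of < 50200 nM in this assay, at which 1 of the 2 values shown sits, both sit at limits. Compound 3 `COc1ccc(CNc2nc3cc(N)cc(N)c3nc2-c2ccccc2)cc1` differs from compound 1 by hydrogen in place of methoxy on an aromatic carbon. No readable measured step bears on this change, and compound 1 itself stands only at a limit. Compound 3 is expected at 40000 nM in this assay, range 8000 nM to 100000 nM. The implied step that the limit leaves unreadable from compound 1 to compound 3 is an estimate, with no direction expected beyond the scatter.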

Compound 3, concentration lethal to 50% of the cells: < 100000 nM
Compound 3: no number, only a limit (the forecaster's own chance of this, stated with the estimate: 40%); the middle value does not contradict the limit.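

Compound 1 and compound 3 both stand only at limits of the assay, and the step between them cannot be read. The compounds shown leave open whether methoxy or hydrogen at this place makes any difference in this assay.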